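A Chloro Substituent and Receptor Binding Affinity

The source may report more compounds than this note shows. Statements on the series, on what has been measured and on what is new or still open speak of the compounds shown alone.

Compound 1 `N#C/N=c1\sccn1Cc1cnc(Cl)c(N=[N+]=[N-])c1`: 120 nM
Compound 2 `[N-]=[N+]=Nc1cncc(Cn2ccnc2N[N+](=O)[O-])c1`: 5400 nM
Compound 3 `[N-]=[N+]=Nc1cc(CN2C=CN/C2=C\[N+](=O)[O-])cnc1Cl`: 40 nM

Of the compounds shown here, three have been measured in an assay on M10 cells (Gallus gallus) for binding affinity to Neuronal acetylcholine receptor; alpha4/beta2 (Homo sapiens); a higher number here means a weaker inhibitor, a lower number a stronger inhibitor. Compound 2 gives 5400 nM and stands highest of the three, so it binds most weakly; the nearest number, that of compound 1, lies well below it, beyond the usual scatter, and compound 3 lies further below still. Compound 4 `[N-]=[N+]=Nc1cc(Cn2ccnc2N[N+](=O)[O-])cnc1Cl` has not yet been measured. It differs from compound 2 in one place: chloro in place of hydrogen on an aromatic carbon. Compounds 1 and 3 both carry this chloro group on the shared core and both bind far more tightly than compound 2, though they also differ from it elsewhere, so no single step can be read from them. Even so, a drop in the number well beyond the scatter is expected, an 11-fold lower number from compound 2 to compound 4 (1.03 log units; beyond the scatter). Compound 4 is therefore estimated at 500 nM, with a range from 100 nM to 2500 nM.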

Compound 4, inhibition constant: 300 nM
For compound 4 the middle estimate is 1.7-fold (0.22 log units) above the measured one; the range from low to high includes it.
By their numbers in this assay, from the lowest: compound 3; then compound 1; then compound 4; then compound 2.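

Placed on the aromatic carbon next to the ring nitrogen and ortho to the azido group, a single chloro atom gives an 18-fold lower number from compound 2 to compound 4 (1.26 log units; beyond the scatter) in this assay and so provides the first clean reading of this change, since compound 1 and compound 3 also differ from compound 2 elsewhere. One heavy atom at this position is enough for a large step. Nothing shown here bears on the reason for this step. As far as these compounds go, whether fluoro, bromo, methyl or an amine at the same position would give a similar step remains open, as does the size of the step on the cores of compound 1 and compound 3.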